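Swapping Trifluoromethyl for Trifluoromethoxy on Compound 1

The source may report more compounds than this note shows. Statements on the series, on what has been measured and on what is new or still open speak of the compounds shown alone.

For the measured compounds named here, compound 1 `CNCCN(C)c1nnnn1Cc1cccc(C(F)(F)F)c1` is one of two compounds measured so far. In an assay on cells for inhibition of protein arginine N-methyltransferase 1 (Homo sapiens), read by scintillation counting, with stated times of 15 min and 60 min, tested at 9 uM (on this read-out higher numbers stand for more inhibition at the one concentration tested (going by the name of the read-out) and lower numbers for less inhibition), compound 1 gives 8%, while compound 2 `CNCCN(C)c1nnnn1Cc1ccc(C(F)(F)F)cc1` gives 2%; these two values lie within the usual scatter of each other, so neither stands apart. Compound 3 `CNCCN(C)c1nnnn1Cc1cccc(OC(F)(F)F)c1` differs from compound 1 in a single place: trifluoromethoxy in place of trifluoromethyl on an aromatic carbon. Going by the values given here, no measured pair shows this change, so its effect is unknown. The step from compound 1 to compound 3 is expected to be a number 1 percentage points lower from compound 1 to compound 3 (within the scatter), nothing beyond the scatter. Compound 3 is therefore estimated at 7%, with a range from -4% to 18%.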

Compound 3, a percentage reported as inhibition, at one concentration (the size of the read-out at that concentration, not a potency): 12%
Estimate against measurement, compound 3: 5 percentage points below; the measured number falls inside the stated range.
By their numbers in this assay, from the lowest: compounds 2, 1 and 3 (each within the scatter of the next).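

Putting trifluoromethoxy in place of trifluoromethyl on this aromatic carbon, meta to a large group, gives a number 4 percentage points higher from compound 1 to compound 3 (within the scatter) in this assay. The added oxygen, which brings one hydrogen-bond acceptor to the group, therefore does not separate the two compounds at the one concentration tested. No measurement here bears on the cause of this small step. From the compounds shown here alone, whether an amine or a carboxylic acid on this same carbon would give a number beyond the scatter of compound 1 remains open, as does the outcome for a longer chain there.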